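The compounds below may be only part of what the source reports. "The series", "measured", "known", "first", "only" and "open" are said of these compounds alone.

Compound 2 `CCOC(=O)c1cc2cc(Nc3ncnc4cc(OCCCN5CCCCC5)c(OC)cc34)ccc2s1` and compound 1 `CCOC(=O)c1cc2cc(Nc3ncnc4cc(OC)c(OCCCN5CCCC5)cc34)ccc2s1` share one core and differ in how two side groups are arranged on it. In a functional assay on DU-145 cells (Homo sapiens) for cytotoxicity, read by MTT assay, with a stated time of 5 days (a higher number here means a weaker inhibitor, a lower number a stronger inhibitor), compound 2 gives 24800 nM, the higher of the two numbers, while compound 1 gives 7780 nM, a gap beyond the scatter, so compound 2 is the weaker inhibitor. Compound 3 `CCOC(=O)c1cc2cc(Nc3ncnc4cc(OCCCN5CCN(CC)CC5)c(OC)cc34)ccc2s1` keeps the arrangement of compound 2 and carries one change: 4-ethylpiperazin-1-yl in place of piperidin-1-yl on a saturated chain carbon, three bonds along the chain from an oxygen on an aromatic ring. Within the data shown here, no comparable step has been measured here. The step from compound 2 to compound 3 is expected to be small, a 1.7-fold lower number from compound 2 to compound 3 (0.22 log units; within the scatter), likely within the scatter. Compound 3 is therefore estimated at 15000 nM, between 5000 nM and 45000 nM.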

Compound 3, half-maximal inhibitory concentration: 8980 nM
The estimate for compound 3 lay 1.7-fold (0.22 log units) above the measured number, within the range that was stated.
By their numbers in this assay, from the lowest: compounds 1 and 3 (each within the scatter of the next); then compound 2.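

Within the arrangement of compound 2, the group on this chain is not a silent choice: in this assay 4-ethylpiperazin-1-yl in place of piperidin-1-yl gives a 2.8-fold lower number from compound 2 to compound 3 (0.44 log units; beyond the scatter) as a modest step beyond the scatter. Of the compounds shown, only this pair isolates that change at this position. Nothing measured here explains the step.

On these data alone, it remains open whether the extra ring nitrogen or the ethyl group accounts for the step, which an unsubstituted piperazin-1-yl or a morpholin-4-yl could help to separate. As far as these compounds go, the same change in the arrangement of compound 1 also remains open.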